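Swapping chloro for bromo on a halogenated phenyl ring

This account rests on a few compounds, and the source may have more. Where it says the series, first, only, none or still open, it means among the compounds named here.

Compound 1 `O=[N+]([O-])c1ccc(N/C(=N\O)c2ccccc2Br)c2nonc12` gives 80 nM in an assay on isolated protein for inhibition of Indoleamine 2,3-dioxygenase 1 (Homo sapiens), read by spectrophotometry, with a stated time of 1 h; on this read-out higher numbers stand for weaker inhibition and lower numbers for stronger inhibition.
Compound 2 `O=[N+]([O-])c1ccc(N/C(=N\O)c2ccc(Cl)cc2)c2nonc12` gives 113 nM in this assay.

Compound 2 and compound 1 lie within the usual scatter of each other, so neither can be called the stronger inhibitor on these two numbers. Within the data shown here, the only measured step is a 1.4-fold higher number from compound 1 to compound 2 (0.15 log units; within the scatter), in which 4-chlorophenyl replaced 2-bromophenyl on the carbon that carries a double bond to nitrogen; that exchange of one halogenated phenyl for another left the read-out essentially unchanged.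

Compound 3 `O=[N+]([O-])c1ccc(N/C(=N\O)c2ccc(Br)cc2)c2nonc12` differs from compound 2 by bromo in place of chloro on an aromatic carbon. Among the measured compounds shown here, no measured step exchanges one halogen for another at a single spot, so the expectation rests on the one step that did alter this ring, which stayed within the scatter. A step of no size beyond the scatter is therefore expected in this assay, with no clear direction.

Compound 3 is estimated at 100 nM, within a range from 50 nM to 200 nM. This estimate means an expected step of a 1.1-fold lower number from compound 2 to compound 3 (0.05 log units; within the scatter).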

Compound 3, half-maximal inhibitory concentration: 117 nM
The estimate for compound 3 lay 1.2-fold (0.07 log units) below the measured number; the measured number falls inside the stated range.
By their numbers in this assay, from the lowest: compounds 1, 2 and 3 (each within the scatter of the next).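

In this assay, among these compounds, the exchange of chloro for bromo on an aromatic carbon, para to a large group, gives a 1.0-fold higher number from compound 2 to compound 3 (0.02 log units; within the scatter) and offers the first direct comparison of two halogens at a single spot; at this spot, the two cannot be told apart. Among the compounds shown here, the other new step, a 1.5-fold higher number from compound 1 to compound 3 (0.17 log units; within the scatter), keeps bromo on the phenyl ring and changes 2-bromophenyl to 4-bromophenyl, so it is the first comparison of the same halogen at two places on that ring, and these two compounds cannot be separated either. No measurement is available to explain why these three numbers lie so close together.

As far as these compounds go, all three compounds carry a single halogen on the phenyl ring, so it remains open whether this spot would tolerate a very different group, such as an amine, a carboxylic acid or a longer chain like butoxy. From the compounds shown here alone, it also remains open how a plain unsubstituted phenyl ring, or fluoro or iodo at the same spot, would compare with chloro and bromo on this read-out.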